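The source may hold more compounds than are shown below. What is called first, only, known or untested is meant among the compounds shown, and "the series" means these compounds.

Compound 1 `CC(Sc1nc2nn(C3COC3)cc2c(=O)n1-c1ccccc1)c1ccccc1`: 109 nM
Compound 2 `COc1cccc(C(C)Sc2nc3c(cnn3C)c(=O)n2-c2ccccc2)c1`: 451 nM

Both were run in an assay on isolated protein for inhibition of aldehyde dehydrogenase 1A1 (Homo sapiens); on this read-out lower numbers stand for stronger inhibition and higher numbers for weaker inhibition. Compound 2 stands at the higher of the two numbers; its nearest neighbour is compound 1, whose number is lower by a gap beyond the usual scatter. The two differ in more than one place, so nothing about a single change can be read from that gap.

Compound 3 `COc1ccc(C(C)Sc2nc3c(cnn3C)c(=O)n2-c2ccccc2)cc1` has not yet been measured. It differs from compound 2 in one place: 4-methoxyphenyl in place of 3-methoxyphenyl on a saturated chain carbon bound to a saturated chain carbon and a sulfur. Among the measured compounds shown here, no step between measured compounds shows what this exchange does in this assay, so no direction can be drawn from the data; the expected step is small, within the scatter, or none at all. Compound 3 is therefore expected to give about 450 nM in this assay, with a likely range from 150 nM to 1350 nM. The estimated step of a 1.0-fold lower number from compound 2 to compound 3 (0.00 log units; within the scatter) is expected to stay within the scatter.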

Compound 3, half-maximal inhibitory concentration: 352 nM
Estimate against measurement, compound 3: 1.3-fold (0.11 log units) above; low and high end bracket the measured number.
By their numbers in this assay, from the lowest: compound 1; then compounds 3 and 2 (each within the scatter of the next).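

In this assay, among the compounds shown here, the exchange of 3-methoxyphenyl for 4-methoxyphenyl on a saturated chain carbon bound to a saturated chain carbon and a sulfur gives the first step that can be read at this place (a 1.3-fold lower number from compound 2 to compound 3 (0.11 log units; within the scatter)). Within the scatter, compound 2 and compound 3 cannot be told apart, so for this pair, the read-out does not separate the two methoxyphenyl groups. No measurement shown here offers an explanation for this result.

Going by these compounds, whether an ethoxy group, a hydroxyl or a carboxylic acid in place of the methoxy group would leave the number as undisturbed remains open. Compound 1 differs from both compound 2 and compound 3 in more than one place, so its lower number still cannot be assigned to any single change.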